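The compounds below may be only part of what the source reports. "The series", "measured", "known", "first", "only" and "open" are said of these compounds alone.

Measured compounds:
- compound 1, `COc1ccc2[nH]c(C(=O)N3CC(=O)N(Cc4ccccc4)[C@@H](CN4CCCC4)C3)cc2c1`; in a physicochemical assay for solubility, read by spectrophotometry, in phosphate buffer, with a stated time of 2 h, at pH 7.4 (a lower number here means a less soluble compound, a higher number a more soluble compound), compound 1 gives only a limit, > 25000 nM.
- compound 2, `COc1ccc2[nH]c(C(=O)N3CC(=O)N(Cc4ccccc4)[C@@H](N4CCc5ccccc54)C3)cc2c1`; in this assay compound 2 gives 7000 nM.

Within the data shown here, compound 2 is the only compound of the pair with a real number; the other value is a limit, as the line the limit of > 25000 nM in this assay, at which 1 of the 2 values shown sits, records. Among the measured compounds shown here, the one measured step runs an at least 3.5-fold lower number from compound 1 to compound 2 (0.55 log units; beyond the scatter), so the indoline-bearing compound 2 sits at the lower end of what has been seen.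

Compound 3, `COc1ccc2[nH]c(C(=O)N3CC(=O)N(Cc4ccccc4)[C@@H](CN4CC5CC5C4)C3)cc2c1`, has not yet been measured. It differs from compound 2 in that (a group of 7 heavy atoms (6 carbon, 1 nitrogen; one three-membered non-aromatic ring of carbon only, one five-membered non-aromatic ring with 1 hetero atom) in place of a group of 9 heavy atoms (8 carbon, 1 nitrogen; one five-membered non-aromatic ring with 1 hetero atom, one six-membered aromatic ring of carbon only), on a saturated ring carbon). The entering group is again an amine attached through a single carbon, which brings compound 3 structurally back toward compound 1, whose solubility sat at the limit > 25000 nM. For the measured compounds named here, that step, an at least 3.5-fold lower number from compound 1 to compound 2 (0.55 log units; beyond the scatter), is the only evidence bearing on the change, and read backwards it suggests a modest rise in this assay for compound 3. The expected step is a 2.6-fold higher number from compound 2 to compound 3 (0.41 log units; beyond the scatter). Compound 3 is therefore estimated at 18000 nM, within a range of 7000 nM to 25000 nM.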

Compound 3, solubility: 17500 nM
Estimate against measurement, compound 3: 1.0-fold (0.01 log units) above; the measured number falls inside the stated range.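

In this assay, the step at this saturated ring carbon is a 2.5-fold higher number from compound 2 to compound 3 (0.40 log units; beyond the scatter), so the lower reading of compound 2 does not hold for every amine-bearing group placed here. Among these compounds, compound 3 also supplies the first real number for an amine attached through a single carbon at this place, since the comparison with compound 1 reads only as an at least 1.4-fold lower number from compound 1 to compound 3 (0.15 log units; that floor lies within the scatter). The true size of that gap stays unsettled, because compound 1 gives only a limit: the limit of > 25000 nM in this assay, at which 1 of the 3 values shown sits.

The step from compound 2 to compound 3 changes the six-membered aromatic ring, the carbon link and the ring fused to the amine together, so these compounds do not show which of these changes accounts for the higher number. They also leave open how a 2,3-dihydro-1H-indol-1-yl group attached through a single carbon, or a morpholine or an open-chain diethylamine on that same carbon, would read in this assay.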